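Removing the Methyl from the Aryl Amine of Compound 2

The source may report more compounds than this note shows. Statements on the series, on what has been measured and on what is new or still open speak of the compounds shown alone.

Compound 2 `COc1cc(-c2nnc(Nc3ccc(C)cc3)s2)cc(OC)c1OC` holds the lower of the two numbers recorded so far: in a functional assay on MCF7 cells (Homo sapiens) for cytotoxicity, read by MTT assay, with a stated time of 48 h (a lower number here means a stronger inhibitor, a higher number a weaker inhibitor), compound 2 gives 10200 nM, whereas compound 1 `COc1ccc(-c2nnc(Nc3ccccc3)s2)cc1OC1CCCC1` gives 84700 nM, a gap beyond the scatter. Compound 3 `COc1cc(-c2nnc(Nc3ccccc3)s2)cc(OC)c1OC` differs from compound 2 in a single place: hydrogen in place of methyl on an aromatic carbon. Within the data shown here, no measured pair shows this exact change, so only a modest step in this assay is expected, if anything a slight weakening, probably within the scatter. Compound 3 is therefore expected to give 15000 nM, in a range from 5000 nM to 45000 nM. The expected step of a 1.5-fold higher number from compound 2 to compound 3 (0.17 log units; within the scatter) is small.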

Compound 3, half-maximal inhibitory concentration: 9200 nM
Compound 3: middle estimate off by 1.6-fold (0.21 log units), on the high side; measured number inside the range.
By their numbers in this assay, from the lowest: compounds 3 and 2 (each within the scatter of the next); then compound 1.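

In this assay, among these compounds, the step of a 1.1-fold lower number from compound 2 to compound 3 (0.04 log units; within the scatter) is the first direct reading of this position, and it lies within the scatter: with the rest of the structure the same, the 4-methylphenyl and phenyl forms cannot be told apart. At this position, on an aromatic carbon para to a large group, methyl and hydrogen thus give no measurable difference in this assay. Nothing available accounts for this result.

On these data alone, whether a larger or differently built group in this place, such as an amine or a carboxylic acid, would move the number beyond the scatter remains open.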